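Swapping a cyclic imide for a difluoroacetamide chain

This account rests on a few compounds, and the source may have more. Where it says the series, first, only, none or still open, it means among the compounds named here.

Compound 1, `O=C1CNC(=O)N1C[C@H]1CN(c2ccc(-n3cc(-c4ccccn4)cn3)c(F)c2)C(=O)O1`, has the lowest of the two numbers measured in a physicochemical assay for lipophilicity, read by HPLC, measured as octanol-water partition (on this read-out lower numbers stand for lower lipophilicity and higher numbers for higher lipophilicity), giving 1.25. Its neighbour compound 2, `CS(=O)(=O)NC[C@H]1CN(c2ccc(-n3cc(-c4ccccn4)cn3)c(F)c2)C(=O)O1`, gives 1.38. Compound 3, `O=C(NC[C@H]1CN(c2ccc(-n3cc(-c4ccccn4)cn3)c(F)c2)C(=O)O1)C(F)F`, is unmeasured; it differs from compound 1 by ((difluoromethyl)carbonyl)amino in place of 2,5-dioxoimidazolidin-1-yl on a saturated chain carbon bound to a saturated ring carbon. Within the data shown here, the one step that bears on this, a number 0.13 log units higher from compound 1 to compound 2 (within the scatter), also replaced that ring with an open chain carrying one hydrogen-bond donor and stayed within the scatter. For compound 3 a small rise is therefore expected, around a number 0.35 log units higher from compound 1 to compound 3 (beyond the scatter), giving an estimate of 1.6 within the range 1.2 to 2.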

Compound 3, partition coefficient: 1.9
The estimate for compound 3 lay 0.30 log units below the measured number; the measured number falls inside the stated range.
By their numbers in this assay, from the lowest: compounds 1 and 2 (each within the scatter of the next); then compound 3.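

In this assay the group on this saturated chain carbon can move the number beyond the scatter: the new group gives a number 0.65 log units higher from compound 1 to compound 3 (beyond the scatter) and also a number 0.52 log units higher from compound 2 to compound 3 (beyond the scatter), whereas the earlier step stayed within it. Losing the ring is therefore not the whole story, since compound 2 and compound 3 both have an open chain and differ only in methylsulfonyl versus (difluoromethyl)carbonyl on the amine nitrogen. Nothing available accounts for the rise. The compounds shown leave open what the fluorine atoms contribute apart from the carbonyl. An acetyl or a trifluoroacetyl group on that amine nitrogen would separate the two.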